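Triazole series on breast cancer cells: outlook for compound 3

The compounds below may be only part of what the source reports. "The series", "measured", "known", "first", "only" and "open" are said of these compounds alone.

Measured compounds:
compound 1, `COc1cc(OC)cc(-n2cc(-c3ccc(OC)c(O)c3)nn2)c1`: > 10000 nM
compound 2, `COc1ccc(-c2cn(-c3cc(OC)c(OC)c(OC)c3)nn2)cc1OC`: "not determined" (no result reported)

In a functional assay on MDA-MB-231 cells (Homo sapiens) for cytotoxicity, read by MTT assay (a lower number here means a stronger inhibitor, a higher number a weaker inhibitor), compound 1 gives > 10000 nM, which is a limit of the assay and not a number. Compound 2 has no result in this assay, so it has no number of its own to stand on. Within the data shown here, the only other value in the set is the limit of > 10000 nM in this assay, at which 1 of the 2 values shown sits, and that is where the measured side of this series rests.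

Compound 3, `COc1cc(OC)cc(-n2cc(-c3ccc(OC)c(OC)c3)nn2)c1`, differs from compound 2 by hydrogen in place of methoxy on an aromatic carbon. Among the measured compounds shown here, no step between two measured compounds is available to calibrate this change, so the size and direction of the step in this assay cannot be read from the data; with a single measured compound sitting at the limit, nothing beyond the usual scatter can be claimed in either direction.

On that footing compound 3 is expected to land near the limit as well, with a fair chance that only a limit is reported again. The estimate for compound 3 in this assay is 15000 nM, with a range from 3000 nM to 60000 nM.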

Compound 3, half-maximal inhibitory concentration: > 1000 nM
Compound 3 ended at the assay's limit; the forecaster's own chance of this, stated with the estimate: 60%; the middle value is on the limit's open side.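

In this assay compound 3 gives > 1000 nM, which is a limit of the assay. Compound 1 gives > 10000 nM, also a limit. Among these compounds, no step from compound 1 to compound 3 can be read from these two limits. The compounds shown leave open whether methyl in place of hydrogen on an oxygen on an aromatic ring changes the result in this assay.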